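The source may report more compounds than this note shows. Statements on the series, on what has been measured and on what is new or still open speak of the compounds shown alone.

Measured compounds:
- Compound 1, `Cc1ccccc1-n1cc(-c2cccc(NS(=O)(=O)c3c[nH]c(=O)[nH]c3=O)c2)nn1`, in a functional assay on SGC-7901 cells (Homo sapiens) for antiproliferative activity, read by MTT assay, with a stated time of 24 h (on this read-out lower numbers stand for stronger inhibition and higher numbers for weaker inhibition), compound 1 gives 9230 nM.
- Compound 2, `Cc1cccc(-n2cc(-c3cccc(NS(=O)(=O)c4c[nH]c(=O)[nH]c4=O)c3)nn2)c1`, in this assay compound 2 gives 9100 nM.
- Compound 3, `Cc1ccccc1-n1cc(-c2ccc(NS(=O)(=O)c3c[nH]c(=O)[nH]c3=O)cc2)nn1`, in this assay compound 3 gives 13600 nM.

Compound 1 and compound 2 share one core and differ only in the group on the triazole nitrogen: 3-methylphenyl in place of 2-methylphenyl on an aromatic nitrogen. This change gave a 1.0-fold lower number from compound 1 to compound 2 (0.01 log units; within the scatter), so the two values are within the scatter and show no order between them. Compound 3 carries the same 2-methylphenyl as compound 1 but on a different core; the difference between the two cores is not broken down here. The value of compound 3 stands within the scatter of both compound 1 and compound 2, so the three measured compounds are not separated in this assay.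

Compound 4, `Cc1cccc(-n2cc(-c3ccc(NS(=O)(=O)c4c[nH]c(=O)[nH]c4=O)cc3)nn2)c1`, is not yet measured. It relates to compound 3 as compound 2 relates to compound 1: 3-methylphenyl in place of 2-methylphenyl on an aromatic nitrogen. The place lines of the two changes read the same word for word, so this is the same kind of change on the core of compound 3. Because a 1.0-fold lower number from compound 1 to compound 2 (0.01 log units; within the scatter) was within the scatter, the step from compound 3 to compound 4 in this assay is expected to be about as small, a 1.0-fold lower number from compound 3 to compound 4 (0.00 log units; within the scatter), resting on that single earlier pair alone. Compound 4 is therefore estimated at 13500 nM, with a likely range from 6500 nM to 28000 nM.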

Compound 4, half-maximal inhibitory concentration: 17500 nM
Compound 4: the middle estimate sits 1.3-fold (0.11 log units) below what was measured; low and high end bracket the measured number.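

In this assay, 3-methylphenyl in place of 2-methylphenyl on an aromatic nitrogen gives a 1.3-fold higher number from compound 3 to compound 4 (0.11 log units; within the scatter), so on the core of compound 3 the change again stays inside the usual scatter. Set beside the earlier pair, the two steps do not differ, and in this series the change carries from one core to the other as a step too small to read: the same change on two cores in this assay, a 1.0-fold lower number (0.01 log units; within the scatter) from compound 1 to compound 2 and a 1.3-fold higher number (0.11 log units; within the scatter) from compound 3 to compound 4, 1.3-fold (0.12 log units) apart, within the scatter of two such steps This does not show that the change is without any effect, since a small real step could lie hidden in the scatter, and two pairs on two cores say nothing about any further core.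

The compounds shown leave open whether the group on the aromatic nitrogen matters at all, as only the two methylphenyl groups appear there, and an unsubstituted phenyl, a chlorophenyl, a benzyl group or a phenyl bearing a carboxylic acid would test that. Also open, as far as these compounds go, is whether the two cores stay inseparable with such groups in place, and whether the flat picture holds in other cell lines or at other exposure times.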